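A few compounds are considered here, and "the series" means these few. Any claim that something is new, unique, unknown or untested is made for them only; others in the source may bear on it.

Working notes on the series. Compound 1 `Clc1ccc(C(c2c[nH]c3ccc(Br)cc23)c2c[nH]c3ccc(Br)cc23)cc1` and compound 2 `Brc1ccc(C(c2c[nH]c3ccc(Br)cc23)c2c[nH]c3ccc(Br)cc23)cc1` share one core and differ in a single place: bromo in place of chloro on an aromatic carbon. In a functional assay on A549 cells (Homo sapiens) for inhibition, read by MTT assay, with a stated time of 48 h (on this read-out higher numbers stand for weaker inhibition and lower numbers for stronger inhibition), compound 1 gives 8500 nM. In this assay compound 2 gives 5600 nM. The step of a 1.5-fold lower number from compound 1 to compound 2 (0.18 log units; within the scatter) lies within the scatter, so the two values are read as the same. Compound 3 `O=[N+]([O-])c1ccc2[nH]cc(C(c3ccc(Cl)cc3)c3c[nH]c4ccc([N+](=O)[O-])cc34)c2c1` carries a different core; the difference between the two cores is not broken down here. In this assay compound 3 gives only a limit, > 100000 nM. Compound 4 `O=[N+]([O-])c1ccc2[nH]cc(C(c3ccc(Br)cc3)c3c[nH]c4ccc([N+](=O)[O-])cc34)c2c1` has not yet been measured in this assay. It stands to compound 3 as compound 2 stands to compound 1: bromo in place of chloro on an aromatic carbon. The place of the change is described in the same words in both pairs, so the change is the same one, made this time on the core of compound 3; among the compounds shown it occurs two times in all. For the measured compounds named here, because compound 3 sits at the limit of > 100000 nM in this assay, at which 1 of the 3 values shown sits, the step from compound 3 to compound 4 cannot be set beside the measured one as a number, and the only guide is that the same change moved compound 1 to compound 2 by a step within the scatter. On that basis the step from compound 3 to compound 4 is expected to be a step that the limit leaves unreadable from compound 3 to compound 4, most likely ending again at a limit rather than a number. Compound 4 is therefore expected to give about 150000 nM in this assay, with a range from 50000 nM to 500000 nM.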

Compound 4, half-maximal inhibitory concentration: > 100000 nM
Compound 4 was reported as a limit (the forecaster's own chance of this, stated with the estimate: 80%); the middle value is on the limit's open side.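

In this assay compound 4 gives > 100000 nM, a limit and not a number. Compound 3 also stands at a limit, so no step from compound 3 to compound 4 can be read: the limit of > 100000 nM in this assay, at which 2 of the 4 values shown sit.

The compounds shown leave open whether bromo in place of chloro changes the read-out at all on the core of compound 3, and where the true values of these two compounds lie.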